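A few compounds are considered here, and "the series" means these few. Any claim that something is new, unique, unknown or untested is made for them only; others in the source may bear on it.

Compound 1 `COc1nc(F)nc2c1ncn2[C@H]1C[C@H](N=[N+]=[N-])[C@@H](CO)O1` is the starting point. In an ADME assay on Vero cells (Chlorocebus sabaeus) for cytotoxicity, with a stated time of 5 days (a higher number here means a weaker inhibitor, a lower number a stronger inhibitor), compound 1 gives > 100000 nM, which is a limit of the assay and not a number. Compound 2 `COc1nc(OC)c2ncn([C@H]3C[C@H](N=[N+]=[N-])[C@@H](CO)O3)c2n1`, with methoxy in place of fluoro on an aromatic carbon, gives > 100000 nM, which is also a limit. Everything measured so far therefore stands at the limit of > 100000 nM in this assay, at which 2 of the 2 values shown sit.

Compound 3 `[N-]=[N+]=N[C@H]1C[C@H](n2cnc3c(Cl)nc(F)nc32)O[C@@H]1CO` carries a different change to compound 1: chloro in place of methoxy on an aromatic carbon. In words, this is chloro in place of methoxy on an aromatic carbon, next to the ring nitrogen and ortho to a fused ring.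

Going by the values given here, only one measured step bears on this, and it is a step that the two limits leave unreadable from compound 1 to compound 2. It involves no chloro group and gives no size to carry over. Since that swap on the core, seen in a step that the two limits leave unreadable from compound 1 to compound 2, yielded no readable number, compound 3 is expected to stay at or near the limit. Any move is expected to be modest and toward a lower number, and the expected change is an at least 1.2-fold lower number from compound 1 to compound 3 (0.09 log units; that floor lies within the scatter). For compound 3 the estimate is 80000 nM, with an expected range from 20000 nM to 100000 nM.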

Compound 3, half-maximal inhibitory concentration: 21800 nM
Compound 3: the middle estimate sits 3.7-fold (0.56 log units) above what was measured, within the range that was stated.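

In this assay, chloro in place of methoxy on this aromatic carbon, next to the ring nitrogen and ortho to a fused ring, brings the first readable value among the compounds shown, with an at least 4.5-fold lower number from compound 1 to compound 3 (0.66 log units; beyond the scatter). That size is only a floor: compound 1 gives > 100000 nM, which is a limit of the assay and not a number. The earlier step between compound 1 and compound 2 cannot be read and concerns a different group, so this is the first sign that a single swap on the shared core can bring a compound off the limit: the limit of > 100000 nM in this assay, at which 2 of the 3 values shown sit.

As far as these compounds go, what stays open is whether this result belongs to chloro alone, or whether another group on the same carbon, such as an amine, a bromo group or a longer chain, would also give a readable value. From the compounds shown here alone, with one readable value in the set, the true size of the step and any trend across groups at this position remain unknown.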